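The compounds below may be only part of what the source reports. "The series", "measured", "known", "first", "only" and "open" are said of these compounds alone.

Working notes on the thromboxane series.

Compound 3, `CCSCC1C2CCC(O2)C1C/C=C\CCCC(=O)O`, gives 5400 nM in a functional assay on a cell-free system (plasma) for inhibition of thromboxane A2 receptor (Homo sapiens) (a higher number here means a weaker inhibitor, a lower number a stronger inhibitor), and stands at the low end of the three measured numbers. Compound 1, `O=C(O)CCC/C=C\CC1C2CCC(O2)C1CSCCc1ccccc1`, gives 5500 nM in this assay, and the pair sits within the scatter, so no order can be drawn between them: a 1.0-fold lower number from compound 1 to compound 3 (0.01 log units; within the scatter). Compound 2, `CCCCCCCCSCC1C2CCC(O2)C1C/C=C\CCCC(=O)O`, gives 547000 nM, and the step to it is large: a 100-fold lower number from compound 2 to compound 3 (2.01 log units; beyond the scatter); likewise a 99-fold higher number from compound 1 to compound 2 (2.00 log units; beyond the scatter).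

Compound 4, `CCC/C=C\CSCC1C2CCC(O2)C1C/C=C\CCCC(=O)O`, is unmeasured. Relative to compound 3 the change is pent-1-en-1-yl in place of methyl on a saturated chain carbon bound to a sulfur. Among the measured compounds shown here, the measured steps that bear on this are those that vary the group beyond the sulfur: the phenyl-to-hydrogen step was flat, whereas the hexyl-to-hydrogen step was large, so a longer saturated chain on that side is the one change seen to weaken inhibition sharply, while the aryl-bearing chain of compound 1 left the number unchanged. The pent-1-en-1-yl extension of compound 4 is a chain, but shorter than that of compound 2 and unsaturated, so a rise in this assay of intermediate size is expected, a 5.6-fold higher number from compound 3 to compound 4 (0.74 log units; beyond the scatter), because the step of a 100-fold lower number from compound 2 to compound 3 (2.01 log units; beyond the scatter) shows what a full saturated chain costs. Compound 4 is therefore expected to give about 30000 nM, within 6000 nM to 150000 nM.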

Compound 4, half-maximal inhibitory concentration: 5700 nM
The estimate for compound 4 lay 5.3-fold (0.72 log units) above the measured number; measured number outside the range, below it.
By their numbers in this assay, from the lowest: compounds 3, 1 and 4 (each within the scatter of the next); then compound 2.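

Replacing methyl with pent-1-en-1-yl on a saturated chain carbon bound to a sulfur gives no readable difference in this assay, a 1.1-fold higher number from compound 3 to compound 4 (0.02 log units; within the scatter), and the same holds for pent-1-en-1-yl in place of benzyl, a 1.0-fold higher number from compound 1 to compound 4 (0.02 log units; within the scatter), so this position accepts an unsaturated chain as well as it accepts the methyl and benzyl groups. Heptyl remains the only group here that stands apart, a 96-fold lower number from compound 2 to compound 4 (1.98 log units; beyond the scatter), which shows that the large step seen with compound 2 does not extend to every chain placed at this position. No measurement shown accounts for this difference between the pent-1-en-1-yl and heptyl chains.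

The step between these two chains changes length and unsaturation together, so a saturated pentyl chain would be needed to show whether the double bond or the chain length separates compound 4 from compound 2. Also open is how this position responds to a chain ending in a hydroxyl or an amine, as every group shown here is built from carbon and hydrogen alone.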